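Aromatic swap on the shared core: compound 2 to compound 3

The source may report more compounds than this note shows. Statements on the series, on what has been measured and on what is new or still open speak of the compounds shown alone.

compound 1: `COc1ccc(O)c(/C=N/NC(=O)c2ccc(-c3nc4ccccc4s3)cc2)c1`, 6500 nM
compound 2: `O=C(N/N=C\c1ccccn1)c1ccc(-c2nc3ccccc3s2)cc1`, 10200 nM

In an assay on isolated protein for inhibition of Maltase-glucoamylase (Homo sapiens), with a stated time of 15 min (on this read-out lower numbers stand for stronger inhibition and higher numbers for weaker inhibition), compound 2 gives 10200 nM, and compound 1 gives 6500 nM; the two lie within the scatter of each other, so no order can be read from them. Compound 3, `O=C(N/N=C/c1ccc(O)cc1)c1ccc(-c2nc3ccccc3s2)cc1`, carries a group of 9 heavy atoms (7 carbon, 1 nitrogen, 1 oxygen; one six-membered aromatic ring of carbon only) in place of a group of 8 heavy atoms (6 carbon, 2 nitrogen; one six-membered aromatic ring with 1 hetero atom), on an amide-type nitrogen. The entering group shares a hydrogen-bond donor and an all-carbon ring with the group borne by compound 1, whose value 6500 nM sits close to that of compound 2. The step from compound 2 to compound 3 is therefore expected to stay within the scatter, a 1.6-fold lower number from compound 2 to compound 3 (0.20 log units; within the scatter). Compound 3 is estimated at 6500 nM, range 2000 nM to 20000 nM.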

Compound 3, half-maximal inhibitory concentration: 11300 nM
Estimate against measurement, compound 3: 1.7-fold (0.24 log units) below, and the stated range covers the measured number.
By their numbers in this assay, from the lowest: compounds 1, 2 and 3 (each within the scatter of the next).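

At this position, a six-membered aromatic ring with 1 hetero atom and the carbon-only ring of 4-hydroxyphenyl are not told apart in this assay, with a 1.1-fold higher number from compound 2 to compound 3 (0.04 log units; within the scatter). The 4-hydroxyphenyl and 2-hydroxy-5-methoxyphenyl groups on a carbon with a double bond to nitrogen are not told apart either, with a 1.7-fold higher number from compound 1 to compound 3 (0.24 log units; within the scatter). Nothing measured speaks to why these values stay together.

Still open, as far as these compounds go, is whether an amine or a carboxylic acid on this ring would give a step beyond the scatter. A saturated cyclohexyl ring at this position also remains untested in the compounds shown.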